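This account rests on a few compounds, and the source may have more. Where it says the series, first, only, none or still open, it means among the compounds named here.

Measured so far:
- compound 1, `CC(C)(C)Cc1csc(N)c1C(=O)c1ccc(Cl)c(Cl)c1`: 10%
- compound 2, `COc1ccc(-c2sc(N)c(C(=O)c3ccc(Cl)cc3)c2CC(C)(C)C)cc1`: 2%
- compound 3, `COc1ccc(-c2sc(N)c(C(=O)c3cccc(Cl)c3)c2CC(C)(C)C)cc1`: 2%

In an assay on CHO cells for displacement of a labelled ligand from adenosine receptor A3 (Homo sapiens), read by scintillation counting, tested at 10 uM (a higher number here means more inhibition at the concentration tested (going by the name of the read-out), a lower number less inhibition), compound 3 gives 2%, level with compound 2 and together with it the lowest of the three numbers; the gap to compound 1 is within the scatter, so no ordering of the three can be read from these values. Within the data shown here, the one measured step, no change at the digits printed from compound 2 to compound 3 (within the scatter), moved the chloro around the benzoyl ring without effect.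

Compound 4, `COc1ccc(-c2sc(N)c(C(=O)c3ccc(Cl)c(Cl)c3)c2CC(C)(C)C)cc1`, differs from compound 3 by chloro in place of hydrogen on an aromatic carbon. Among the measured compounds shown here, compound 1 carries the same 3,4-dichlorophenyl on its carbonyl carbon and gives 10% in this assay, but it lacks the methoxyphenyl on the core, so no single step connects it to compound 4 and only its value can be set beside those of compounds 2 and 3. For the measured compounds named here, the only directly comparable step is the one from compound 2 to compound 3, which was flat. Adding a second chloro to a ring whose chloro position did not matter is expected to leave the read-out within the scatter, so a number 2 percentage points higher from compound 3 to compound 4 (within the scatter) is the estimated step. Compound 4 is therefore expected to give 4%, in the range -6% to 14%.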

Compound 4, a percentage reported as inhibition, at one concentration (the size of the read-out at that concentration, not a potency): 1%
Estimate against measurement, compound 4: 3 percentage points above; the measured number falls inside the stated range.
By their numbers in this assay, from the lowest: compounds 4, 2, 3 and 1 (each within the scatter of the next).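

In this assay, adding the second chloro, ortho to the existing chloro group, gives a number 1 percentage points lower from compound 3 to compound 4 (within the scatter), and the same change counted from the other monochloro compound gives a number 1 percentage points lower from compound 2 to compound 4 (within the scatter). The 3-chlorophenyl, 4-chlorophenyl and 3,4-dichlorophenyl groups on the carbonyl carbon therefore cannot be told apart here, whether the chloro is moved or a second one is added. Among these compounds, the new pair with compound 1 also gives the first single-place reading of the 4-methoxyphenyl on the core, with the 3,4-dichlorophenyl held constant: a number 9 percentage points lower from compound 1 to compound 4 (within the scatter), so that group cannot be separated from hydrogen at this position either. No evidence is available that bears on why these readings fall as they do.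

On these data alone, it remains open whether a group other than chloro on this ring, such as a nitrile, a carboxylic acid or an amine, would move the read-out beyond the scatter. The same question stands for the aromatic carbon of the core, where a smaller group such as a methyl or a pyridyl ring could take the place of the 4-methoxyphenyl.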